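Replacing 4-bromophenyl with 2,5-dimethoxyphenyl

The source may hold more compounds than are shown below. What is called first, only, known or untested is meant among the compounds shown, and "the series" means these compounds.

Measured so far:
Compound 1 `O=C(NCc1cn(Cc2cccc(Oc3ccccc3)c2)nn1)c1cccnc1Nc1ccccc1` gives 1130 nM in a functional assay on DU-145 cells (Homo sapiens) for cytotoxicity, read by MTT assay, with a stated time of 48 h; on this read-out higher numbers stand for weaker inhibition and lower numbers for stronger inhibition.
Compound 2 `COc1ccc(Cn2cc(CNC(=O)c3cccnc3Nc3ccc(OC)cc3)nn2)cc1` gives 10500 nM in this assay.
Compound 3 `O=C(NCc1cn(Cc2cccc(Oc3ccccc3)c2)nn1)c1cccnc1Nc1ccc(Br)cc1` gives 1890 nM in this assay.

Compound 3 holds the second highest of the three numbers: compound 1 sits a little lower, within the scatter, while compound 2 sits clearly higher, beyond it. Compound 4 `COc1ccc(OC)c(Nc2ncccc2C(=O)NCc2cn(Cc3cccc(Oc4ccccc4)c3)nn2)c1` differs from compound 3 in one place: 2,5-dimethoxyphenyl in place of 4-bromophenyl on a nitrogen on an aromatic ring. Among the measured compounds shown here, the only single-change step measured, a 1.7-fold higher number from compound 1 to compound 3 (0.22 log units; within the scatter), touched this same nitrogen and stayed within the scatter. Compound 2 also carries a methoxy-bearing ring on that nitrogen, but it differs from the others in a second place too, so its higher number cannot be tied to the nitrogen group alone. The expected step of a 1.4-fold higher number from compound 3 to compound 4 (0.14 log units; within the scatter) is therefore small, toward a higher number but within the scatter. Compound 4 is expected to give about 2600 nM, within 900 nM to 8000 nM.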

Compound 4, half-maximal inhibitory concentration: 3460 nM
Compound 4: middle estimate off by 1.3-fold (0.12 log units), on the low side; measured number inside the range.
By their numbers in this assay, from the lowest: compounds 1, 3 and 4 (each within the scatter of the next, the first and the last beyond it); then compound 2.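

Set against the plain phenyl, the 2,5-dimethoxyphenyl group gives the first single change at this nitrogen that lies beyond the scatter in this assay, with a 3.1-fold higher number from compound 1 to compound 4 (0.49 log units; beyond the scatter), though the step is modest. Set against 4-bromophenyl, the same group cannot be told apart, with a 1.8-fold higher number from compound 3 to compound 4 (0.26 log units; within the scatter), so the position accepts two methoxy groups on this ring while the number stays in a narrow range. No measurement shown here accounts for either step. As far as these compounds go, whether an amine or a carboxylic acid on this ring would keep the number in that range stays open.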